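A few compounds are considered here, and "the series" means these few. Any claim that something is new, unique, unknown or untested is made for them only; others in the source may bear on it.

Measured in an ADME assay on MT4 cells (Homo sapiens) for cytotoxicity, read by MTT assay; on this read-out lower numbers stand for higher toxicity in this test and higher numbers for lower toxicity in this test:
Compound 1 `CCOC(=O)c1ccc(NC(=O)CSc2ncncc2-c2cccc3ccccc23)c(Br)c1`: 211000 nM
Compound 2 `CCOC(=O)c1ccc(NC(=O)CSc2ncncc2-c2cccc3ccccc23)c(Cl)c1`: 195000 nM

Within the data shown here, compound 2 stands at 195000 nM, and the two numbers cannot be ranked, since the only measured step, a 1.1-fold lower number from compound 1 to compound 2 (0.03 log units; within the scatter), lies within the scatter. Compound 3 `CCOC(=O)C(C)NC(=O)c1ccc(NC(=O)CSc2ncncc2-c2cccc3ccccc23)c(Cl)c1` has (1-(ethoxycarbonyl)ethyl)amino in place of ethoxy on a carbonyl carbon. That measured step swaps chloro for bromo on an aromatic carbon, so it offers no direct guide to this larger change. The expected move in this assay is therefore small, a 1.3-fold lower number from compound 2 to compound 3 (0.11 log units; within the scatter), and not beyond the scatter. For compound 3 the estimated value is 150000 nM, with an expected range of 50000 nM to 350000 nM.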

Compound 3, half-maximal cytotoxic concentration: 35600 nM
The estimate for compound 3 lay 4.2-fold (0.62 log units) above the measured number, and the stated range ends above it.
By their numbers in this assay, from the lowest: compound 3; then compounds 2 and 1 (each within the scatter of the next).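

The carbonyl carbon is a position where a change does register in this assay: (1-(ethoxycarbonyl)ethyl)amino in place of ethoxy gives a 5.5-fold lower number from compound 2 to compound 3 (0.74 log units; beyond the scatter), which here means higher toxicity in this test. The earlier swap of chloro for bromo on an aromatic carbon gave no readable difference. Nothing available explains this step. Still open, going by these compounds, is which part of the larger group carries the step. A plain methylamino group, or a carboxylic acid in place of its ethyl ester, at the same place would help to separate these parts.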